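Swapping an oxadiazole for a thiadiazole on a chromone thioether

This account rests on a few compounds, and the source may have more. Where it says the series, first, only, none or still open, it means among the compounds named here.

Measured so far:
- compound 1, `Cc1nnc(SCc2coc3ccc(Cl)cc3c2=O)s1`, 9700 nM
- compound 2, `Cc1nnc(SCc2coc3ccccc3c2=O)o1`, 1400 nM

Of the compounds shown here, two have been tested in a functional assay on HeLa cells (Homo sapiens) for cytotoxicity, read by MTT assay, with a stated time of 72 h; on this read-out lower numbers stand for stronger inhibition and higher numbers for weaker inhibition. Compound 2 holds the lowest of the two numbers; the nearest, compound 1, sits at a higher number, and the gap between them lies beyond the usual scatter. Going by the values given here, compound 1 and compound 2 differ in more than one place, so no single step between them can be read off; their two values show only that compound 2 is the more potent of the pair in this assay.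

Compound 3, `Cc1nnc(SCc2coc3ccccc3c2=O)s1`, has not yet been measured. It carries 5-methyl-1,3,4-thiadiazol-2-yl in place of 5-methyl-1,3,4-oxadiazol-2-yl on a sulfur, so the core and the methylene thioether link of compound 2 are kept. Among the compounds with values here, the only thiadiazole analogue measured, compound 1, also carries a chloro substituent that compound 3 lacks, so no clean precedent exists for this exchange alone.

Compound 3 is expected to show a moderate rise in the number relative to compound 2, on the order of a 2.3-fold higher number from compound 2 to compound 3 (0.36 log units; beyond the scatter), though a result within the scatter would not surprise. The estimate for compound 3 in this assay is 3200 nM, with a range from 900 nM to 11000 nM.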

Compound 3, half-maximal inhibitory concentration: 2300 nM
The estimate for compound 3 lay 1.4-fold (0.14 log units) above the measured number; measured number inside the range.
By their numbers in this assay, from the lowest: compounds 2 and 3 (each within the scatter of the next); then compound 1.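

In this assay, 5-methyl-1,3,4-thiadiazol-2-yl in place of 5-methyl-1,3,4-oxadiazol-2-yl on a sulfur gives a 1.6-fold higher number from compound 2 to compound 3 (0.22 log units; within the scatter) and so stays within the scatter, which means that the two rings cannot be told apart at this position in this read-out. Compound 3 also supplies the comparison that compound 1 lacked, since hydrogen in place of chloro on an aromatic carbon gives a 4.2-fold lower number from compound 1 to compound 3 (0.63 log units; beyond the scatter) and this step lies beyond the scatter; of the two steps that can be read, the chloro exchange is therefore the one that registers, and the ring exchange is not. No measurement accompanies these results that would explain either step.

The compounds shown leave open whether chloro would have a similar effect on compound 2, where the oxadiazole ring stands in place of the thiadiazole. They also leave open what other groups on the sulfur would do, such as a ring bearing an amine or a carboxylic acid instead of the methyl, or a longer chain in its place.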